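The compounds below may be only part of what the source reports. "The series", "measured", "known", "first", "only" and "open" are said of these compounds alone.

Compound 1 `COc1ccccc1OS(=O)(=O)/C=C/c1ccccc1Cl` gives 76 nM in an assay on U2OS cells for activation of nuclear factor erythroid 2-related factor 2 (Homo sapiens), read by chemiluminescence, with a stated time of 6 h; on this read-out lower numbers stand for an effect already at smaller amounts and higher numbers for an effect only at larger amounts of compound. Compound 2 `COc1ccc(OS(=O)(=O)/C=C/c2ccccc2Cl)cc1` gives 237 nM. Compound 3 `COc1ccccc1OS(=O)(=O)/C=C/c1cccc(Cl)c1` gives 698 nM.

Compound 3 stands highest of the three numbers in this assay, with compound 2 nearer to it and compound 1 furthest below. Compound 4 `COc1ccccc1OS(=O)(=O)/C=C/c1ccc(Cl)cc1` differs from compound 3 by 4-chlorophenyl in place of 3-chlorophenyl on a double-bonded chain carbon bound to a double-bonded chain carbon. Among the compounds with values here, the only measured step that bears on this change is a 9.2-fold higher number from compound 1 to compound 3 (0.96 log units; beyond the scatter), where a shift of the chlorine on the same ring raised the number beyond the scatter. Within the data shown here, no measured pair covers the move from 3-chlorophenyl to 4-chlorophenyl, so the direction rests on that single step. Compound 4 is therefore expected to give a number at or somewhat above that of compound 3. The expected step is a 1.4-fold higher number from compound 3 to compound 4 (0.16 log units; within the scatter). Compound 4 is estimated at 1000 nM, in a range of 300 nM to 3500 nM.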

Compound 4, half-maximal effective concentration: 1330 nM
For compound 4 the middle estimate is 1.3-fold (0.12 log units) below the measured one, and the stated range covers the measured number.
By their numbers in this assay, from the lowest: compound 1; then compound 2; then compounds 3 and 4 (each within the scatter of the next).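

In this assay, 4-chlorophenyl in place of 3-chlorophenyl gives a 1.9-fold higher number from compound 3 to compound 4 (0.28 log units; within the scatter), so these two compounds are not told apart, while 4-chlorophenyl in place of 2-chlorophenyl gives an 18-fold higher number from compound 1 to compound 4 (1.24 log units; beyond the scatter). Among compounds 1, 3 and 4, only the 2-chlorophenyl compound now stands apart from the other two at this place on the chain. Nothing available here accounts for that difference.

Going by these compounds, whether an amine or a carboxylic acid in place of the chlorine would keep a number near that of compound 1 at 76 nM remains open.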